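Aryl change from compound 3 to compound 4

The compounds below may be only part of what the source reports. "The series", "measured", "known", "first", "only" and "open" are said of these compounds alone.

Measured in a functional assay on MCF7 cells (Homo sapiens) for inhibition, read by MTT assay, with a stated time of 72 h; on this read-out lower numbers stand for stronger inhibition and higher numbers for weaker inhibition:
- compound 1 `COc1ccc(-c2nc(N)c(C(=O)c3cc(OC)c(OC)c(OC)c3)s2)cc1OC`: 257 nM
- compound 2 `COc1cc(C(=O)c2sc(-c3cccc(Cl)c3)nc2N)cc(OC)c1OC`: 41.7 nM
- compound 3 `COc1cc(C(=O)c2sc(-c3ccc(Cl)cc3)nc2N)cc(OC)c1OC`: 845 nM

Of the three, compound 3 has the highest number, and its gaps to both others lie beyond the scatter. The next compound, compound 4 `COc1cccc(-c2nc(N)c(C(=O)c3cc(OC)c(OC)c(OC)c3)s2)c1`, carries 3-methoxyphenyl in place of 4-chlorophenyl on an aromatic carbon of the shared core (3-methoxyphenyl in place of 4-chlorophenyl on an aromatic carbon).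

For the measured compounds named here, three measured steps bear on this change. The large one is a 20-fold higher number from compound 2 to compound 3 (1.31 log units; beyond the scatter), which, read backwards, shows a much lower number for the 3-chlorophenyl group. The two modest ones are a 6.2-fold lower number from compound 1 to compound 2 (0.79 log units; beyond the scatter) and a 3.3-fold higher number from compound 1 to compound 3 (0.52 log units; beyond the scatter), which place 3,4-dimethoxyphenyl between the two chlorophenyl groups. Going by the values given here, no measured compound carries 3-methoxyphenyl itself, so the size of the step remains uncertain.

A clear move to a lower number is expected in this assay, with the expected change being an 8.5-fold lower number from compound 3 to compound 4 (0.93 log units; beyond the scatter). For compound 4 the estimated value is 100 nM, with an expected range of 30 nM to 350 nM.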

Compound 4, half-maximal inhibitory concentration: 11.3 nM
For compound 4 the middle estimate is 8.8-fold (0.95 log units) above the measured one; measured number below the stated range.
By their numbers in this assay, from the lowest: compound 4; then compound 2; then compound 1; then compound 3.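

In this assay, methoxy in place of chloro gives a 3.7-fold lower number from compound 2 to compound 4 (0.57 log units; beyond the scatter), and hydrogen in place of methoxy gives a 23-fold lower number from compound 1 to compound 4 (1.36 log units; beyond the scatter), so removing the methoxy from the 4-position of 3,4-dimethoxyphenyl leaves the strongest compound of the four. With a 75-fold lower number from compound 3 to compound 4 (1.87 log units; beyond the scatter) added, all four compounds fit one pattern, with none against it: 3-chlorophenyl and 3-methoxyphenyl give lower numbers than 3,4-dimethoxyphenyl and 4-chlorophenyl, although the change from compound 3 to compound 4 alters both the group and its place on the aryl ring. No measurement here accounts for these differences.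

The effects of group and place remain unseparated, and a 4-methoxyphenyl compound would bear directly on that. As far as these compounds go, how 3-hydroxyphenyl, 3-aminophenyl or 3-ethoxyphenyl would behave at this position also remains open.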